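Trimming an Ethyl Group from a Measured Inhibitor

A few compounds are considered here, and "the series" means these few. Any claim that something is new, unique, unknown or untested is made for them only; others in the source may bear on it.

compound 1 `CCC1c2cc(Cl)ccc2C(=O)N1c1cccnc1` — 121 nM
compound 2 `Cc1ccc(C(=O)Nc2cccnc2)cc1` — > 3000 nM

Within the data shown here, in an assay on cells for inhibition of cytochrome P450 11B2, mitochondrial (Homo sapiens), read by HTRF (a higher number here means a weaker inhibitor, a lower number a stronger inhibitor), compound 1 gives 121 nM, the only real number in hand. For compound 2 the value > 3000 nM is a limit of the assay, not a number (the limit of > 3000 nM in this assay, at which 1 of the 2 values shown sits). Compound 3 `O=C1c2ccc(Cl)cc2CN1c1cccnc1` differs from compound 1 by hydrogen in place of ethyl on a saturated ring carbon. Among the measured compounds shown here, no step between two measured compounds exists here, so the effect of this change is not anchored by any measured comparison. The step of a 5.0-fold higher number from compound 1 to compound 3 (0.70 log units; beyond the scatter) is what is expected, a loss of potency beyond the usual scatter. Compound 3 is estimated at 600 nM, with a range from 150 nM to 2500 nM.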

Compound 3, half-maximal inhibitory concentration: 179 nM
Beside the measured number, compound 3's estimate is 3.4-fold (0.53 log units) above it; the range from low to high includes it.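

In this assay, hydrogen in place of ethyl on the saturated ring carbon gives a 1.5-fold higher number from compound 1 to compound 3 (0.17 log units; within the scatter) and the two compounds cannot be told apart in this measurement. The ethyl group is therefore not required for the level of inhibition seen with compound 1, and this ring carbon can carry a plain hydrogen instead.

Going by these compounds, whether a methyl, a phenyl ring, an amine or a carboxylic acid at this carbon would keep that level stays open. Nothing measured here offers a reason for this result.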